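A few compounds are considered here, and "the series" means these few. Any claim that something is new, unique, unknown or untested is made for them only; others in the source may bear on it.

Measured so far:
Compound 1, `N#CC1=C(N)Oc2c(c3nc4ccccc4nc3c3ccccc23)C12C(=O)N(Cc1cnnn1-c1ccc(Cl)cc1)c1ccccc12`: in a functional assay on A549 cells (Homo sapiens) for antiproliferative activity, read by MTT assay, with a stated time of 48 h (a higher number here means a weaker inhibitor, a lower number a stronger inhibitor), compound 1 gives > 50000 nM, which is a limit of the assay.
Compound 2, `CC(=O)Nc1ccc(-n2nncc2CN2C(=O)C3(C(C#N)=C(N)Oc4c3c3nc5ccccc5nc3c3ccccc43)c3ccccc32)cc1`: in this assay compound 2 gives > 50000 nM, again a limit and not a number.
Compound 3, `CCc1ccccc1-n1nncc1CN1C(=O)C2(C(C#N)=C(N)Oc3c(N)cc4nc5ccccc5nc4c32)c2ccccc21`: in this assay compound 3 gives 24600 nM.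

Compound 3 is thus the only one of the three with a number in this assay; the other two values sit at the limit of > 50000 nM in this assay, at which 2 of the 3 values shown sit. For the measured compounds named here, the single step between measured compounds is a step that the two limits leave unreadable from compound 1 to compound 2; both of its ends are limits, so its size cannot be read.

The unmeasured compound 4, `COc1ccc(OC)c(-n2nncc2CN2C(=O)C3(C(C#N)=C(N)Oc4c(N)cc5nc6ccccc6nc5c43)c3ccccc32)c1`, differs from compound 3 by 2,5-dimethoxyphenyl in place of 2-ethylphenyl on an aromatic nitrogen. Going by the values given here, no measured step touches this exchange: the only step available concerns a different substitution and is itself unreadable. There is therefore no ground for expecting a step beyond the scatter in either direction, and the estimate for compound 4 simply stays close to compound 3, with a wide range and a fair chance that only a limit is returned. Compound 4 is expected to give 30000 nM in this assay, between 10000 nM and 100000 nM. The expected step is a 1.2-fold higher number from compound 3 to compound 4 (0.09 log units; within the scatter).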

Compound 4, half-maximal inhibitory concentration: 28100 nM
The estimate for compound 4 lay 1.1-fold (0.03 log units) above the measured number; low and high end bracket the measured number.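

For the compounds shown here, this exchange gives the first readable step. In this assay, 2,5-dimethoxyphenyl in place of 2-ethylphenyl on the aromatic nitrogen gives a 1.1-fold higher number from compound 3 to compound 4 (0.06 log units; within the scatter), so the two compounds cannot be told apart in this read-out. The entering group carries oxygen and hydrogen-bond acceptors and the leaving group carries neither, yet in this one pair, with the six-membered aromatic ring of carbon kept at that nitrogen, that difference comes with no step beyond the scatter.

As far as these compounds go, a single pair cannot show whether this position tolerates other groups, so it stays open whether an amine or a carboxylic acid on that ring, or a longer chain in place of the ethyl group, would give a step beyond the scatter. The remaining step, from compound 1 to compound 2, cannot be read, and the other substitutions on the aromatic ring therefore remain without a measured size, with the assay limit still covering part of the set: the limit of > 50000 nM in this assay, at which 2 of the 4 values shown sit.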